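Triazole Aryl Exchange: From Compound 2 to Compound 4

A few compounds are considered here, and "the series" means these few. Any claim that something is new, unique, unknown or untested is made for them only; others in the source may bear on it.

The series shares one core, seen in compound 1 `COc1ccc(/C=C\C(=O)O)c(OCc2cn(-c3ccc(NC(=O)c4ccccc4)cc3)nn2)c1CC=C(C)C`, compound 2 `COc1ccc(-n2cc(COc3c(/C=C\C(=O)O)ccc(OC)c3CC=C(C)C)nn2)cc1` and compound 3 `COc1ccc(/C=C\C(=O)O)c(OCc2cn(-c3ccccc3C(=O)N3CCC(O)C3)nn2)c1CC=C(C)C`, and differs only in the aryl group carried on the triazole nitrogen. In a functional assay on PC-3 cells (Homo sapiens) for cytotoxicity, read by MTT assay, with a stated time of 24 h (a lower number here means a stronger inhibitor, a higher number a weaker inhibitor), compound 3 gives 36200 nM, a weak result. For compound 1 the entry in this assay reads "not determined" (no result reported), and for compound 2 it reads "not determined" (no result reported), so compound 2 stands without a number of its own, and the only figure in the set belongs to compound 3.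

Compound 4 `COc1ccc(/C=C\C(=O)O)c(OCc2cn(-c3cccc([N+](=O)[O-])c3)nn2)c1CC=C(C)C` arises from compound 2 by a single exchange: 3-nitrophenyl in place of 4-methoxyphenyl on an aromatic nitrogen. Within the data shown here, no measured pair in the set shows what such an exchange does in this assay, so the size and direction of the step cannot be read from the data; it may well lie within the scatter.

Given that the one measured relative, compound 3, shows only weak inhibition at 36200 nM, compound 4 is expected to be similarly weak, with an estimated 35000 nM and a range from 8000 nM to 150000 nM.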

Compound 4, half-maximal inhibitory concentration: 42100 nM
Estimate against measurement, compound 4: 1.2-fold (0.08 log units) below; measured number inside the range.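

Among these compounds, no step from compound 2 to compound 4 can be read, as compound 2 has no single number to set against compound 4. The compounds shown leave open what 3-nitrophenyl in place of 4-methoxyphenyl does to cytotoxicity. No supporting evidence bears on this result.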